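Stretching a Phenyl Into a Two-Carbon Phenylethenyl Arm

A few compounds are considered here, and "the series" means these few. Any claim that something is new, unique, unknown or untested is made for them only; others in the source may bear on it.

Among the measured compounds shown here, compound 1 `CC(=O)c1cc(-c2ccccc2)cc2cc(-c3ccccc3)[nH]c12` was tested in a functional assay on HeLa cells (Homo sapiens) for cytotoxicity, read by MTT assay, with a stated time of 2 days, tested at 100 uM (a lower number here means a stronger effect, a higher number a weaker effect of the compound at the concentration tested), and compound 1 gives 51.4%, the lowest of the two numbers measured so far. For the measured compounds named here, compound 2 `CC(=O)c1cc(-c2ccccc2)cc2cc(-c3ccc(F)cc3)[nH]c12` gives 68.3%, and the only measured step, a number 16.9 percentage points higher from compound 1 to compound 2 (beyond the scatter), concerns a different place on the molecule. Compound 3 `CC(=O)c1cc(/C=C/c2ccccc2)cc2cc(-c3ccccc3)[nH]c12` differs from compound 1 by 2-phenylethenyl in place of phenyl on an aromatic carbon. Going by the values given here, no measured step mirrors this swap of 2-phenylethenyl for phenyl, so the expected step is a number 3.6 percentage points higher from compound 1 to compound 3 (within the scatter), no larger than the scatter. Compound 3 is therefore estimated at 55%, with a range from 35% to 78%.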

Compound 3, a percentage reported as activity, at one concentration (the size of the read-out at that concentration, not a potency): 21.3%
The estimate for compound 3 lay 33.7 percentage points above the measured number; the measured number lies below the stated range.
By their numbers in this assay, from the lowest: compound 3; then compound 1; then compound 2.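

Putting 2-phenylethenyl in place of phenyl gives a number 30.1 percentage points lower from compound 1 to compound 3 (beyond the scatter) in this assay. Among the compounds shown here, this shows that the carbon meta to the acetyl group is a place where a change can lower the number sharply, whereas the only earlier step, at a different place, raised it. No measurement here explains why the longer arm has this effect.

Still open, from the compounds shown here alone, is whether the double bond matters or the added length alone, which a saturated 2-phenylethyl arm at this carbon would help settle. Also open, going by these compounds, is how an amine on the arm's phenyl ring would move the number.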